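Chloro to fluoro swap on the benzyl ether of compound 1

The source may hold more compounds than are shown below. What is called first, only, known or untested is meant among the compounds shown, and "the series" means these compounds.

Compound 1 `Fc1cc(COC2CCN(Cc3ccc4[nH]cnc4c3)CC2)ccc1Cl` gives 70 nM in an assay on membranes from HEK293 cells for displacement of a labelled ligand from Sigma intracellular receptor 2 (Homo sapiens); a lower number here means a stronger inhibitor, a higher number a weaker inhibitor. Among the three compounds measured so far it holds the second highest number. Compound 3 `Cc1cc(NC(=O)CN2CCC(OCc3ccc(F)c(F)c3)CC2)ccc1F` is nearest, with 123 nM in this assay, a gap that lies within the scatter. Compound 2 `Fc1ccc(CN2CCCC3(CCN(Cc4cc5ccc(Cl)cc5[nH]4)C3)C2)cc1F` is furthest, with 30 nM in this assay, a lower number that lies beyond the scatter. Going by the values given here, no two of the measured compounds differ in one place only, so no single step between measured compounds is available.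

Compound 4 `Fc1ccc(COC2CCN(Cc3ccc4[nH]cnc4c3)CC2)cc1F` is not yet measured. It differs from compound 1 by fluoro in place of chloro on an aromatic carbon, so that the 4-chloro-3-fluorophenyl becomes a 3,4-difluorophenyl. Compound 2 and compound 3 both carry that 3,4-difluorophenyl on other cores, and their numbers lie on either side of compound 1, which gives no direction for this change. The expected step from compound 1 to compound 4 in this assay is small, towards a somewhat higher number, and may well stay inside the scatter. The estimate for compound 4 is 110 nM, with a range from 40 nM to 300 nM. That estimate for compound 4 corresponds to an expected step of a 1.6-fold higher number from compound 1 to compound 4 (0.20 log units; within the scatter).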

Compound 4, inhibition constant: 166 nM
Beside the measured number, compound 4's estimate is 1.5-fold (0.18 log units) below it; low and high end bracket the measured number.
By their numbers in this assay, from the lowest: compound 2; then compounds 1, 3 and 4 (each within the scatter of the next, the first and the last beyond it).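

Notes on the first single-place step in the series: in this assay, fluoro in place of chloro on the benzyl ether's aromatic ring, turning the 4-chloro-3-fluorophenyl into a 3,4-difluorophenyl on an otherwise unchanged compound, gives a 2.4-fold higher number from compound 1 to compound 4 (0.38 log units; beyond the scatter) and this modest step lies beyond the scatter. This position, ortho to a fluoro group and para to a large group, therefore responds to the identity of the halogen, with chloro going with the lower number in this pair, something compound 2 and compound 3 could not show, as they carry the 3,4-difluorophenyl on other cores. No available data bear on what lies behind the step, so it stands as an observation on this one pair.

The compounds shown leave open whether the same swap moves the number in the same direction on the cores of compound 2 and compound 3. They also leave open how this position takes groups other than chloro and fluoro, such as bromo, methyl, methoxy, trifluoromethyl or nitrile, and so whether the lower number seen with chloro extends beyond that single atom.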